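Trifluoromethyl on the fused ring of compound 3

The compounds below may be only part of what the source reports. "The series", "measured", "known", "first", "only" and "open" are said of these compounds alone.

Compound 1 `NCC1(c2cccc(-c3ccnc4[nH]ncc34)c2)CCC1`: 17 nM
Compound 2 `NCC1(c2cccc(-c3ccnc4[nH]ncc34)c2)CCCCC1`: 30 nM
Compound 3 `NCC1(c2cccc(-c3ccnc4[nH]ncc34)c2)CCOCC1`: 9 nM

These three compounds share one core and differ only in the saturated ring carrying the aminomethyl group. In an assay for inhibition of protein kinase C theta type (Homo sapiens), read by scintillation counting and 33P incorporation, with a stated time of 60 min, in the presence of a further agent that is not named here (on this read-out lower numbers stand for stronger inhibition and higher numbers for weaker inhibition), compound 3 sits at the low end of the three numbers; compound 1 lies within the scatter of it, and only compound 2 stands beyond that scatter.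

Compound 4 `NCC1(c2cccc(-c3ccnc4[nH]nc(C(F)(F)F)c34)c2)CCOCC1` has not been measured. It differs from compound 3 by trifluoromethyl in place of hydrogen on an aromatic carbon. Within the data shown here, no measured pair shows this kind of change, so its effect here is unknown; a step of modest size in either direction, or none beyond the scatter, is possible. Compound 4 is expected to give about 15 nM, between 4 nM and 60 nM, which is an expected step of a 1.7-fold higher number from compound 3 to compound 4 (0.22 log units; within the scatter).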

Compound 4, inhibition constant: 9 nM
Compound 4: the middle estimate sits 1.7-fold (0.22 log units) above what was measured, within the range that was stated.
By their numbers in this assay, from the lowest: compounds 3, 4, 1 and 2 (each within the scatter of the next, the first and the last beyond it).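

In this assay, trifluoromethyl in place of hydrogen on an aromatic carbon of the five-membered aromatic ring gives no change at the digits printed from compound 3 to compound 4 (within the scatter) and so leaves the number where it was. This position, the same in compounds 1 to 3, therefore accepts a group of 4 heavy atoms with no step beyond the scatter. Nothing at hand explains this result.

On these data alone, whether a methyl group, an amine or a carboxylic acid would be accepted at this carbon remains open. So does whether trifluoromethyl would have the same effect on compound 1 or compound 2.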